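Sulfonyl substituent change from compound 2 to compound 3

This account rests on a few compounds, and the source may have more. Where it says the series, first, only, none or still open, it means among the compounds named here.

Measured compounds:
compound 1 `CCS(=O)(=O)NC(=O)c1ccc(Nc2nc(NC3(c4ccc(Cl)cc4)CC3)nc(OCC(F)(F)F)n2)cc1` — in a physicochemical assay for permeability, using PAMPA, at pH 7.4 (a lower number here means that the compound crosses the layer more slowly, a higher number that the compound crosses the layer faster), compound 1 gives 28 nm/s
compound 2 `COC(=O)NCCS(=O)(=O)NC(=O)c1ccc(Nc2nc(NC3(c4ccc(Cl)cc4)CC3)nc(OCC(F)(F)F)n2)cc1` — in this assay compound 2 gives 39 nm/s

Compound 2 cannot be told apart from compound 1 on the numbers shown: the one step available, a 1.4-fold higher number from compound 1 to compound 2 (0.14 log units; within the scatter), lies within the scatter, so no ordering of the two is claimed.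

Compound 3 `Cc1ccccc1S(=O)(=O)NC(=O)c1ccc(Nc2nc(NC3(c4ccc(Cl)cc4)CC3)nc(OCC(F)(F)F)n2)cc1` is the next member. The change is 2-methylphenyl in place of 2-((methoxycarbonyl)amino)ethyl on a sulfonyl sulfur. Among the measured compounds shown here, the only measured step, a 1.4-fold higher number from compound 1 to compound 2 (0.14 log units; within the scatter), alters the chain on the sulfonyl sulfur and stays within the scatter; no measured step places an aromatic group on that sulfur, so nothing bears directly on this change. The shared core is kept. The expectation for compound 3 is therefore weakly held: a step of a 1.5-fold higher number from compound 2 to compound 3 (0.19 log units; within the scatter) is expected, a modest rise in this assay. Compound 3 is estimated at 60 nm/s, with a range from 25 nm/s to 140 nm/s.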

Compound 3, apparent permeability: 265 nm/s
Beside the measured number, compound 3's estimate is 4.4-fold (0.65 log units) below it, outside the stated range (above it).
By their numbers in this assay, from the lowest: compounds 1 and 2 (each within the scatter of the next); then compound 3.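

In this assay, the sulfonyl sulfur now shows a step beyond the scatter: 2-methylphenyl gives a 6.8-fold higher number from compound 2 to compound 3 (0.83 log units; beyond the scatter) in place of 2-((methoxycarbonyl)amino)ethyl, and a 9.5-fold higher number from compound 1 to compound 3 (0.98 log units; beyond the scatter) in place of ethyl. The change between the two saturated chains, a 1.4-fold higher number from compound 1 to compound 2 (0.14 log units; within the scatter), stays within the scatter, so among these compounds only the aromatic group on that sulfur separates from the rest, with the shared core kept. Nothing measured here accounts for the size of these steps.

On these data alone, whether the rise belongs to the aromatic ring or to its methyl group stays open, and a plain phenyl on the sulfonyl sulfur would address that. A benzyl group or a longer alkyl chain such as hexyl on the same sulfur also remains to be placed against these values.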